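A few compounds are considered here, and "the series" means these few. Any claim that something is new, unique, unknown or untested is made for them only; others in the source may bear on it.

In a functional assay on MDA-MB-435 cells (Homo sapiens) for antiproliferative activity, read by sulforhodamine B assay, with a stated time of 48 h (on this read-out lower numbers stand for stronger inhibition and higher numbers for weaker inhibition), the three measured compounds gave the following numbers:

Compound 1 `COc1cc(-c2nn(-c3ccc(NC(=O)Nc4ccc(Cl)c(Cl)c4)cc3)cc2-c2ccncc2)ccc1Cl`: 2870 nM
Compound 2 `COc1cc(-c2nn(-c3ccc(NC(=O)Nc4ccc(Cl)c(C(F)(F)F)c4)cc3)cc2-c2ccncc2)ccc1Cl`: 1600 nM
Compound 3 `O=C(Nc1ccc(-n2cc(-c3ccncc3)c(-c3ccc(Cl)c(O)c3)n2)cc1)Nc1ccc(Cl)c(C(F)(F)F)c1`: 1320 nM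

Compound 3 holds the lowest of the three numbers. Its nearest neighbour is compound 2, separated by a 1.2-fold lower number from compound 2 to compound 3 (0.08 log units; within the scatter), a gap within the scatter; compound 1 lies furthest off, and the two values of compound 1 and compound 3 show a gap beyond the scatter. Compound 4 `O=C(Nc1ccc(-n2cc(-c3ccncc3)c(-c3ccc(Cl)c(O)c3)n2)cc1)c1cc(Cl)cc(Cl)c1` differs from compound 3 by 3,5-dichlorophenyl in place of (4-chloro-3-(trifluoromethyl)phenyl)amino on a carbonyl carbon, so the urea of compound 3 becomes an amide in compound 4.

Neither measured step touches this part of the molecule. The step of a 1.8-fold lower number from compound 1 to compound 2 (0.25 log units; within the scatter) exchanged one aromatic substituent for another on the outer ring, and the step of a 1.2-fold lower number from compound 2 to compound 3 (0.08 log units; within the scatter) altered the oxygen on the other end of the core; both stayed within the scatter. Among the compounds with values here, the change to compound 4 removes the amino group that those earlier steps left untouched, and no measured pair shows what such a change does in this assay . The expectation therefore rests on the small size of every step seen so far, and is held loosely, with a wide range.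

Compound 4 is expected to give about 2000 nM, between 500 nM and 8000 nM. The expected step is a 1.5-fold higher number from compound 3 to compound 4 (0.18 log units; within the scatter).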

Compound 4, half-maximal inhibitory concentration: 3780 nM
Compound 4: the middle estimate sits 1.9-fold (0.28 log units) below what was measured, and the stated range covers the measured number.
By their numbers in this assay, from the lowest: compounds 3, 2, 1 and 4 (each within the scatter of the next, the first and the last beyond it).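

In this assay, within the data shown here, the exchange on the carbonyl carbon gives the first step that lies beyond the scatter: a 2.9-fold higher number from compound 3 to compound 4 (0.46 log units; beyond the scatter). The two earlier steps, one on an aromatic substituent of the outer ring and one on the oxygen at the other end of the core, both stayed within it, so this position is the only one shown where a change separates two compounds clearly, although the step is modest. The data shown offer no measurement that accounts for this step.

In this single exchange, the urea becomes an amide, the amino group with its hydrogen-bond donor leaves, and the ring substituents change from chloro and trifluoromethyl to two chlorines, so the compounds shown do not tell which of these changes carries the step. Also open, from the compounds shown here alone, is what this carbonyl carbon would give with a saturated amine such as piperidine or morpholine in place of the aromatic group.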